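Methoxy replaces hydrogen on the phenoxy ring

The compounds below may be only part of what the source reports. "The series", "measured", "known", "first", "only" and "open" are said of these compounds alone.

Compound 2 `c1ccc(Oc2ccc3c(NCCCNCc4ccco4)ccnc3c2)cc1` gives 15200 nM in an ADME assay on HepG2 cells (Homo sapiens) for cytotoxicity, read by luminescence, CellTiter-Glo and ATP content, with a stated time of 72 h (on this read-out higher numbers stand for an effect only at larger amounts of compound and lower numbers for an effect already at smaller amounts), the highest of the two numbers measured. Going by the values given here, compound 1 `CC(C)(C)c1ccc(Oc2ccc3c(NCCCNCc4ccco4)ccnc3c2)cc1` gives 3100 nM; the step of a 4.9-fold higher number from compound 1 to compound 2 (0.69 log units; beyond the scatter) is the only measured change at this ring. Compound 3 `COc1ccc(Oc2ccc3c(NCCCNCc4ccco4)ccnc3c2)cc1` differs from compound 2 by methoxy in place of hydrogen on an aromatic carbon. Among the compounds with values here, the single step at the same place links the bare ring to a higher number, so a smaller group there is expected to shift the number modestly downward, likely near the scatter. Compound 3 is estimated at 9000 nM, range 3500 nM to 20000 nM, an expected step of a 1.7-fold lower number from compound 2 to compound 3 (0.23 log units; within the scatter).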

Compound 3, half-maximal effective concentration: 5300 nM
Compound 3: the middle estimate sits 1.7-fold (0.23 log units) above what was measured, within the range that was stated.
By their numbers in this assay, from the lowest: compounds 1 and 3 (each within the scatter of the next); then compound 2.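

In this assay, phenoxy to 4-methoxyphenoxy gives a 2.9-fold lower number from compound 2 to compound 3 (0.46 log units; beyond the scatter), so at this place the lower number relative to the bare ring is no longer seen with tert-butyl alone. The two groups are not separated here: a 1.7-fold higher number from compound 1 to compound 3 (0.23 log units; within the scatter) is a difference that does not exceed the usual scatter. Nothing available gives a reason for either step.

Open, going by these compounds, is whether an amine or a carboxylic acid at this place would also go with a lower number. Also open, on these data alone, is whether methoxy would have the same effect elsewhere on this ring.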